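Dinitrophenyl to dihydroxyphenyl swap on two urea cores

The source may report more compounds than this note shows. Statements on the series, on what has been measured and on what is new or still open speak of the compounds shown alone.

Compound 2 `O=C(NCCNS(=O)(=O)c1ccc(-c2ccccc2Oc2ccc([N+](=O)[O-])c([N+](=O)[O-])c2)s1)Nc1cc(Cl)cc(Cl)c1` and compound 1 `O=C(NCCNS(=O)(=O)c1ccc(-c2ccccc2Oc2ccc(O)c(O)c2)s1)Nc1cc(Cl)cc(Cl)c1` share one core; compound 3 `O=C(NCCNS(=O)(=O)c1ccc(-c2ccccc2Oc2ccc([N+](=O)[O-])c([N+](=O)[O-])c2)s1)Nc1cc(C(F)(F)F)cc(C(F)(F)F)c1` and compound 4 `O=C(NCCNS(=O)(=O)c1ccc(-c2ccccc2Oc2ccc(O)c(O)c2)s1)Nc1cc(C(F)(F)F)cc(C(F)(F)F)c1` share another. The difference between the two cores is not broken down here. In a functional assay on RS4-11 cells (Homo sapiens) for inhibition, read by CCK-8 assay, with a stated time of 48 h (a higher number here means a weaker inhibitor, a lower number a stronger inhibitor), compound 2 gives 2100 nM, compound 1 gives 4500 nM, and compound 3 gives 2400 nM. The change from compound 2 to compound 1 is 3,4-dihydroxyphenyl in place of 3,4-dinitrophenyl on an oxygen on an aromatic ring, and it made a 2.1-fold higher number from compound 2 to compound 1 (0.33 log units; beyond the scatter). The same change, (3,4-dihydroxyphenyl in place of 3,4-dinitrophenyl on an oxygen on an aromatic ring), takes compound 3 to compound 4, at the same kind of place. Among the compounds with values here, the step expected in this assay is a 2.1-fold higher number from compound 3 to compound 4 (0.32 log units; beyond the scatter), resting on the single earlier instance a 2.1-fold higher number from compound 2 to compound 1 (0.33 log units; beyond the scatter), a thin basis. Compound 4 is therefore estimated at 5000 nM, between 2500 nM and 10000 nM.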

Compound 4, half-maximal inhibitory concentration: 4900 nM
The estimate for compound 4 lay 1.0-fold (0.01 log units) above the measured number; measured number inside the range.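

In this assay, 3,4-dihydroxyphenyl in place of 3,4-dinitrophenyl on the oxygen gives a 2.0-fold higher number from compound 3 to compound 4 (0.31 log units; beyond the scatter). The step carries over between the two cores shown, with no difference in size beyond the scatter: the same change on two cores in this assay, a 2.1-fold higher number (0.33 log units; beyond the scatter) from compound 2 to compound 1 and a 2.0-fold higher number (0.31 log units; beyond the scatter) from compound 3 to compound 4, 1.0-fold (0.02 log units) apart, within the scatter of two such steps. This covers two cores only and does not show that the step would hold on any other core, nor does it explain why the number moves in this direction.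

Open, as far as these compounds go, is whether both groups on the ring are needed for the step, as compounds with a single nitro or a single hydroxyl group would show. Also open, from the compounds shown here alone, is how an amine or a methoxy group would read on this ring in this assay.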